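This account rests on a few compounds, and the source may have more. Where it says the series, first, only, none or still open, it means among the compounds named here.

Among the compounds with values here, compound 1 `CN(C)C1(Cc2ccccc2)CCN(c2cc(C(F)(F)F)ccc2CNC(=O)Nc2cccc3c(=O)[nH]ccc23)CC1` is the one member of this small set with a measured number: in an assay on CHO cells for agonist activity at transient receptor potential cation channel subfamily V member 1 (Homo sapiens), read by scintillation counting, with a stated time of 5 min, in the presence of a further agent that is not named here (a higher number here means that more compound is needed for the effect, a lower number that less compound is needed), compound 1 gives 43.7 nM. Compound 2 `CN(C)C1(Cc2ccccc2)CCN(c2cc(C(F)(F)F)ccc2CNC(=O)Nc2ccc3cccnc3c2)CC1` is reported in this assay only as "not active" (no number reported), with no number behind it. Compound 3 `CN(C)C1(Cc2ccccc2)CCN(c2cc(C(F)(F)F)ccc2CNC(=O)Nc2ccc3cnccc3c2)CC1` stands in the same position: in this assay compound 3 is reported as "not active" (no number reported), so there is no single value from which to measure a step. Compound 4 `CN(C)C1(Cc2ccccc2)CCN(c2cc(C(F)(F)F)ccc2CNC(=O)Nc2cccc3ccncc23)CC1` keeps every atom of compound 3 but joins them differently: isoquinolin-8-yl in place of isoquinolin-6-yl on an amide-type nitrogen. Within the data shown here, with two inactive neighbours and a single active one, no measured step supports a direction for this change. Compound 4 is therefore estimated to give 1500 nM in this assay, within a range from 150 nM to 15000 nM, with a real chance that only inactivity is reported.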

Compound 4, half-maximal effective concentration: "not active" (no number reported)
Compound 4 has no reported number here; no gap can be computed for the estimate.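

Compound 3 and compound 4 are both reported in this assay only as not active, so no step can be read between them. No measurement shown bears on this result. Going by these compounds, whether isoquinolin-6-yl and isoquinolin-8-yl differ at all in activity stays open.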